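Cytotoxicity notes on the methylenecyclopropane series, compound 3 to 4

The source may report more compounds than this note shows. Statements on the series, on what has been measured and on what is new or still open speak of the compounds shown alone.

The series shares a core seen in compound 1 `Nc1nc(NC2CCCCC2)c2ncn(/C=C3/CC3(CO)CO)c2n1`, compound 2 `Nc1nc(NC2CC2)c2ncn(/C=C3/CC3(CO)CO)c2n1` and compound 3 `CC(C)CNc1nc(N)nc2c1ncn2/C=C1/CC1(CO)CO`, differing only in the group on the six-membered aromatic ring. In an ADME assay on MOLT-3 cells (Homo sapiens) for cytotoxicity, with a stated time of 7 days (a higher number here means that more compound is tolerated, a lower number that less compound is tolerated), the entry for compound 1 is "not determined" (no result reported). For compound 2 this assay reports only a limit, > 20000 nM, not a number. Compound 3 likewise has no number: its entry in this assay is "not determined" (no result reported). So compound 3 stands among the entries without a single value, and the one value that exists in the set is the limit described as the limit of > 20000 nM in this assay, at which 1 of the 3 values shown sits.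

Compound 4 `CCCSc1nc(N)nc2c1ncn2/C=C1/CC1(CO)CO` differs from compound 3 in one place: propylsulfanyl in place of isobutylamino on an aromatic carbon. Within the data shown here, no measured step exists between any two compounds, so no direction can be read from data; the expectation is that the change leaves this assay within the usual scatter, with no step beyond it, and that the value is likely to sit at the limit again. The estimate for compound 4 in this assay is 25000 nM, with a range from 8000 nM to 80000 nM.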

Compound 4, half-maximal cytotoxic concentration: > 20000 nM
Compound 4: only a limit was reported; the forecaster's own chance of this, stated with the estimate: 70%; the middle value does not contradict the limit.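

No new step can be read: compound 2 and compound 4 both carry only a limit in this assay, which leaves the step between them unreadable: the limit of > 20000 nM in this assay, at which 2 of the 4 values shown sit.

The compounds shown leave open whether propylsulfanyl, cyclopropylamino or isobutylamino on the shared core changes the half-maximal cytotoxic concentration at all, since no single number stands among them.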